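The source may hold more compounds than are shown below. What is called first, only, known or untested is meant among the compounds shown, and "the series" means these compounds.

Compound 2 `CCNC(=O)Nc1ccc(-c2nc3n(Cc4c(F)cccc4F)cc(C(=O)NCc4cn(CCOCCN=[N+]=[N-])nn4)c(=O)n3c2CN(C)Cc2ccccc2)cc1` is the starting point of this step. In a functional assay on CHO cells for antagonist activity at Gonadotropin-releasing hormone receptor (Homo sapiens), read by a luciferase reporter, with a stated time of 30 min (a lower number here means a stronger inhibitor, a higher number a weaker inhibitor), compound 2 gives only a limit, < 10000 nM, and not a number. Compound 3 `CCNC(=O)Nc1ccc(-c2nc3n(Cc4c(F)cccc4F)cc(C(=O)NCc4cn(CCN=[N+]=[N-])nn4)c(=O)n3c2CN(C)Cc2ccccc2)cc1` is its nearest measured neighbour, carrying azido in place of 2-azidoethoxy on a saturated chain carbon, two bonds along the chain from an aromatic nitrogen. In this assay compound 3 likewise gives only a limit, < 10000 nM. The step from compound 2 to compound 3 is therefore unreadable: a step that the two limits leave unreadable from compound 2 to compound 3, since (the limit of < 10000 nM in this assay, at which 2 of the 3 values shown sit). Going by the values given here, compound 1 `CCOC(=O)c1cn(Cc2c(F)cccc2F)c2nc(-c3ccc(NC(=O)NCc4cn(CCN=[N+]=[N-])nn4)cc3)c(CN(C)Cc3ccccc3)n2c1=O`, with a different core substitution pattern, is the only member with a number in this assay, where compound 1 gives 2570 nM.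

Compound 4 `CCNC(=O)Nc1ccc(-c2nc3n(Cc4c(F)cccc4F)cc(C(=O)NCc4cn(CCOCCOCCOCCOCCN=[N+]=[N-])nn4)c(=O)n3c2CN(C)Cc2ccccc2)cc1` differs from compound 2 by 2-(2-(2-azidoethoxy)ethoxy)ethoxy in place of azido on a saturated chain carbon, two bonds along the chain from an oxygen on a saturated carbon. Among the compounds with values here, the only step that bears on a change in the azide-bearing chain is the one from compound 2 to compound 3, and it cannot be sized. Within the data shown here, no measured step indicates a direction, so the step from compound 2 to compound 4 is expected to be small, a step that the limit leaves unreadable from compound 2 to compound 4, with the real chance that this assay again reports only a limit for compound 4. Compound 4 is estimated at 6000 nM, within 1500 nM to 20000 nM.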

Compound 4, half-maximal inhibitory concentration: < 10000 nM
Compound 4 gave a limit, no number; the forecaster's own chance of this, stated with the estimate: 60%; the middle value lies beyond the limit too.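

Compound 2 and compound 4 each give only a limit, so no step between them can be read, since both sit at the same limit: the limit of < 10000 nM in this assay, at which 3 of the 4 values shown sit.

Still open, on these data alone, is whether the length of the azide-bearing chain on the core of compound 2 changes the inhibitory concentration at all.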